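Nitro for Nitrile on Two Antiproliferative Cores

This account rests on a few compounds, and the source may have more. Where it says the series, first, only, none or still open, it means among the compounds named here.

Measured compounds:
compound 1, `CC(O)(CS(=O)(=O)c1ccc(S(F)(F)(F)(F)F)cc1)C(=O)Nc1ccc(C#N)cc1C(F)(F)F`, 19400 nM
compound 2, `CC(O)(CS(=O)(=O)c1ccc(S(F)(F)(F)(F)F)cc1)C(=O)Nc1ccc([N+](=O)[O-])cc1C(F)(F)F`, 18700 nM
compound 3, `CC1(C)C(=O)N(c2ccc(C#N)cc2C(F)(F)F)C(=S)N1c1cccc(S(F)(F)(F)(F)F)c1`, 100000 nM

All three were tested in a functional assay on CWR22R cells (Homo sapiens) for antiproliferative activity, read by propidium iodide staining, with a stated time of 96 h; a higher number here means a weaker inhibitor, a lower number a stronger inhibitor. Compound 1 and compound 2 share one core; compound 3 has another, and the difference between the two cores is not broken down here. Compound 2 differs from compound 1 by nitro in place of cyano on an aromatic carbon. That change gave a 1.0-fold lower number from compound 1 to compound 2 (0.02 log units; within the scatter), so the two values cannot be told apart. Compound 3 stands highest of the three in this assay.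

Compound 4, `CC1(C)C(=O)N(c2ccc([N+](=O)[O-])cc2C(F)(F)F)C(=S)N1c1cccc(S(F)(F)(F)(F)F)c1`, is not yet measured. It differs from compound 3 by nitro in place of cyano on an aromatic carbon, the same change as before. The step from compound 3 to compound 4 is expected to be no change at the digits printed from compound 3 to compound 4 (within the scatter), because the earlier pair shows a 1.0-fold lower number from compound 1 to compound 2 (0.02 log units; within the scatter). Compound 4 is estimated at 100000 nM, between 45000 nM and 200000 nM.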

Compound 4, half-maximal inhibitory concentration: 43900 nM
For compound 4 the middle estimate is 2.3-fold (0.36 log units) above the measured one; measured number outside the range, below it.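

In this assay, nitro in place of cyano gave a 2.3-fold lower number from compound 3 to compound 4 (0.36 log units; beyond the scatter), a modest step beyond the scatter, whereas the same change on the core of compound 1 gave a step within it. Even so, the two steps cannot be told apart: the same change on two cores in this assay, a 1.0-fold lower number (0.02 log units; within the scatter) from compound 1 to compound 2 and a 2.3-fold lower number (0.36 log units; beyond the scatter) from compound 3 to compound 4, 2.2-fold (0.34 log units) apart, within the scatter of two such steps. This is consistent with the change carrying over between these two cores, but two pairs cannot show that it would behave alike on any other core in this series.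

The compounds shown leave open whether an amine or a carboxylic acid on the same aromatic carbon would compare with nitrile and nitro. They also leave open how the nitro-for-nitrile change would behave on a third core.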